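Piperidine 4-substituent: butoxy ether to pivalate ester

The compounds below may be only part of what the source reports. "The series", "measured", "known", "first", "only" and "open" are said of these compounds alone.

Compound 3 `CCCCOC1CCN(c2nc(C(F)(F)F)ccc2CNC(=O)C(C)c2ccc(NS(C)(=O)=O)c(F)c2)CC1` carries the highest number of the three measured, with 3.5 nM in a functional assay on CHO-K1 cells for antagonist activity at transient receptor potential cation channel subfamily V member 1 (Homo sapiens), read by FLIPR; a higher number here means a weaker inhibitor, a lower number a stronger inhibitor. Compound 1 `Cc1ccc(CC2CCN(c3nc(C(F)(F)F)ccc3CNC(=O)C(C)c3ccc(NS(C)(=O)=O)c(F)c3)CC2)cc1` gives 0.2 nM and compound 2 `CC(C(=O)NCc1ccc(C(F)(F)F)nc1N1CCC(Cc2ccc(F)c(F)c2)CC1)c1ccc(NS(C)(=O)=O)c(F)c1` gives 0.2 nM; the steps of an 18-fold higher number from compound 1 to compound 3 (1.24 log units; beyond the scatter) and an 18-fold higher number from compound 2 to compound 3 (1.24 log units; beyond the scatter) show that butoxy on the saturated ring carbon costs heavily against either benzyl group, while no change at the digits printed from compound 1 to compound 2 (within the scatter) is flat. Compound 4 `CC(C(=O)NCc1ccc(C(F)(F)F)nc1N1CCC(OC(=O)C(C)(C)C)CC1)c1ccc(NS(C)(=O)=O)c(F)c1` differs from compound 3 by (tert-butyl)carbonyl in place of butyl on an oxygen on a saturated carbon. Within the data shown here, no measured pair tests an ester against an ether at this oxygen, so only the direction of the benzyl-to-butoxy steps is a guide; a small step is expected, a 1.4-fold higher number from compound 3 to compound 4 (0.15 log units; within the scatter). Compound 4 is expected to give about 5 nM, within 1.5 nM to 20 nM.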

Compound 4, inhibition constant: 2 nM
Compound 4: middle estimate off by 2.5-fold (0.40 log units), on the high side; measured number inside the range.
By their numbers in this assay, from the lowest: compounds 1 and 2 (each within the scatter of the next); then compounds 4 and 3 (each within the scatter of the next).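

At this oxygen, (tert-butyl)carbonyl in place of butyl gives a 1.8-fold lower number from compound 3 to compound 4 (0.24 log units; within the scatter) in this assay and so does not separate the ester from the ether. The ester still falls short of both benzyl groups on the saturated ring carbon, with a 10-fold higher number from compound 2 to compound 4 (1.00 log units; beyond the scatter) and a 10-fold higher number from compound 1 to compound 4 (1.00 log units; beyond the scatter) as its steps. Nothing available explains these gaps.

Open, from the compounds shown here alone, is whether an amine or a carboxylic acid on that saturated ring carbon would match the benzyl compounds. Also open, going by these compounds, is how a longer chain on the oxygen would read.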